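This account rests on a few compounds, and the source may have more. Where it says the series, first, only, none or still open, it means among the compounds named here.

Compound 1 `COc1ccc(/C=C2\c3cc(OC)c(OC)c(OC)c3CC[C@@H]2O)cc1F` and compound 2 `COc1ccc(/C=C2\c3cc(OC)c(OC)c(OC)c3CC[C@@H]2O)cc1[N+](=O)[O-]` share the same core and differ at one aromatic carbon. In a functional assay on HT-29 cells (Homo sapiens) for inhibition, read by MTT assay (a higher number here means a weaker inhibitor, a lower number a stronger inhibitor), compound 1 gives 3 nM and compound 2 gives 1590 nM, so compound 1 has the lower number of the two and is the stronger inhibitor.

Compound 3 `COc1ccc(/C=C2\c3cc(OC)c(OC)c(OC)c3CC[C@H]2O)cc1F` has not yet been measured. Its difference from compound 1 is subtle: the two compounds have the same atoms and bonds and differ only in configuration as drawn: 1 of 2 stereo elements differ; a stereocentre at a saturated ring carbon is drawn S in compound 1 and R in compound 3. Nothing leaves and nothing enters.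

Going by the values given here, only one measured step is available, and it bears on this change only indirectly. The step of a 530-fold higher number from compound 1 to compound 2 (2.72 log units; beyond the scatter) is large, but it comes from nitro in place of fluoro, not from a change in configuration. Among the compounds with values here, it shows that one local change can shift the number a long way in this pair, but no measured pair isolates the stereocentre. A rise is still the more likely outcome, as compound 1 already sits at 3 nM. The expected change is a 6.7-fold higher number from compound 1 to compound 3 (0.82 log units; beyond the scatter), a moderate estimate with wide uncertainty. For compound 3, the estimated value is 20 nM, with an expected range of 2 nM to 300 nM.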

Compound 3, half-maximal inhibitory concentration: 220 nM
Beside the measured number, compound 3's estimate is 11-fold (1.04 log units) below it; low and high end bracket the measured number.
By their numbers in this assay, from the lowest: compound 1; then compound 3; then compound 2.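

Changing only the stereocentre at a saturated ring carbon from S to R produces, in this assay, a 73-fold higher number from compound 1 to compound 3 (1.87 log units; beyond the scatter). The earlier step came from replacing one group with another on an aromatic carbon, so it could not show whether the arrangement in space at this saturated carbon matters by itself. This pair shows that it does, and that a change with nothing leaving and nothing entering can be large in this series; the shift can be assigned to configuration at this carbon alone because of a single structural fact: the fact that compounds 1 and 3 differ only in the configuration as drawn

The compounds shown leave open whether the S-to-R change would have a similar effect with nitro in place of fluoro, and what would follow from changing the second stereo element, which compound 1 and compound 3 share. They also leave open how an amine or a carboxylic acid in place of fluoro on the aromatic carbon would behave in either configuration, and the numbers alone do not explain how configuration at this carbon alters inhibition in these cells.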